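The source may report more compounds than this note shows. Statements on the series, on what has been measured and on what is new or still open speak of the compounds shown alone.

Measured in an ADME assay on GES1 cells (Homo sapiens) for cytotoxicity, read by MTT assay, with a stated time of 24 h; on this read-out higher numbers stand for lower toxicity in this test and lower numbers for higher toxicity in this test:
compound 1 `O=c1[nH]cc(S(=O)(=O)Nc2ccccc2-c2cn(-c3ccccc3F)nn2)c(=O)[nH]1` gives > 100000 nM.
compound 2 `O=c1[nH]cc(S(=O)(=O)Nc2ccccc2-c2cn(-c3cccc(F)c3)nn2)c(=O)[nH]1` gives "not toxic" (no number reported).
compound 3 `Cc1ccccc1-n1cc(-c2cccc(NS(=O)(=O)c3c[nH]c(=O)[nH]c3=O)c2)nn1` gives 21500 nM.

The value of compound 1 is a limit of this assay, not a number. For compound 2 only a word was reported, no number. Among the measured compounds shown here, compound 3 is thus the single compound in this set with a number in this assay. Compound 4 `O=c1[nH]cc(S(=O)(=O)Nc2cccc(-c3cn(-c4cccc(Cl)c4)nn3)c2)c(=O)[nH]1` has not yet been measured. Its change from compound 3 is 3-chlorophenyl in place of 2-methylphenyl on an aromatic nitrogen. For the measured compounds named here, no pair of measured compounds differs in one place, so nothing here shows how such a swap moves the read-out. The step of a 1.2-fold higher number from compound 3 to compound 4 (0.07 log units; within the scatter) is expected to stay within the usual scatter, with no set direction. Compound 4 is estimated at 25000 nM, between 8000 nM and 100000 nM.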

Compound 4, half-maximal cytotoxic concentration: 26200 nM
Compound 4: middle estimate off by 1.0-fold (0.02 log units), on the low side; low and high end bracket the measured number.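

In this assay, the swap gives a 1.2-fold higher number from compound 3 to compound 4 (0.09 log units; within the scatter). Among the compounds shown here, this is the first step that can be read in this set: on this core, 3-chlorophenyl can take the place of 2-methylphenyl on the aromatic nitrogen and the two compounds read alike. Only compound 1 stands at a limit, which is not a number: the limit of > 100000 nM in this assay, at which 1 of the 4 values shown sits.

As far as these compounds go, whether a phenyl ring carrying an amine or a carboxylic acid would move the number at this position stays open. One step also cannot show whether the same swap would read alike on the core of compound 1.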